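From Hydroxy to Methoxy: What to Expect for Compound 4

The source may report more compounds than this note shows. Statements on the series, on what has been measured and on what is new or still open speak of the compounds shown alone.

Measured so far in a functional assay on MCF7 cells (Homo sapiens) for inhibition, read by MTT assay, with a stated time of 2 days; on this read-out higher numbers stand for weaker inhibition and lower numbers for stronger inhibition:
compound 1 `Oc1ccc(/C=C/c2ccccc2O)cc1` gives 21 ug/mL;
compound 2 `Nc1ccc(/C=C/c2ccc(O)cc2)cc1` gives 2.2 ug/mL;
compound 3 `COc1ccccc1/C=C/c1ccc(O)cc1` gives 19 ug/mL.

Compound 3 differs from compound 1 by one change, (methyl in place of hydrogen on an oxygen on an aromatic ring). That change made a step of a 1.1-fold lower number from compound 1 to compound 3 (0.04 log units; within the scatter), so in this assay the two compounds are, in effect, indistinguishable. Compound 2 has a different core, and the difference between the cores of compound 1 and compound 2 is not broken down here; what the values show is that compound 2 has the lowest number of the three, with its gaps to compound 3 and compound 1 both beyond the usual scatter.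

Compound 4 `COc1ccc(/C=C/c2ccc(N)cc2)cc1` has not yet been measured. It differs from compound 2 by methyl in place of hydrogen on an oxygen on an aromatic ring, the same change, at the same kind of place, that turned compound 1 into compound 3. Because that earlier step was a 1.1-fold lower number from compound 1 to compound 3 (0.04 log units; within the scatter), the step from compound 2 to compound 4 is expected to be small as well, estimated at no change at the digits printed from compound 2 to compound 4 (within the scatter). Compound 4 is therefore expected to give about 2.2 ug/mL in this assay, most likely between 0.9 ug/mL and 5.5 ug/mL.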

Compound 4, half-maximal inhibitory concentration: 0.0021 ug/mL
For compound 4 the middle estimate is 1000-fold (3.02 log units) above the measured one; the measured number lies below the stated range.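

In this assay, placing a methyl on the oxygen of the hydroxy group gave a 1000-fold lower number from compound 2 to compound 4 (3.02 log units; beyond the scatter), so this change was not a small step on every core. The same change, hydroxy to methoxy, therefore behaved very differently on the two cores: the same change on two cores in this assay, a 1.1-fold lower number (0.04 log units; within the scatter) from compound 1 to compound 3 and a 1000-fold lower number (3.02 log units; beyond the scatter) from compound 2 to compound 4, 950-fold (2.98 log units) apart, beyond the scatter of two such steps. This shows that, in this series, the size of the step on the core of compound 1 did not predict its size on the core of compound 2, but it does not show which feature of the cores is responsible, and two pairs of compounds set no rule for any other core.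

The compounds shown leave open how a longer chain on the same oxygen, such as ethyl in place of methyl, would behave on the core of compound 2. They also leave open whether a step of this size would remain if a carboxylic acid stood in place of the amine of compound 4.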